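Replacing 4-(dimethylamino)phenyl with 3,4-dimethoxyphenyl

The source may hold more compounds than are shown below. What is called first, only, known or untested is meant among the compounds shown, and "the series" means these compounds.

In a functional assay on PC-3 cells (Homo sapiens) for inhibition, read by sulforhodamine B assay (on this read-out lower numbers stand for stronger inhibition of growth and higher numbers for weaker inhibition of growth), compound 1 `c1ccc(-c2ccc(-c3ccc(-c4nc5ccccc5[nH]4)cc3)cc2)cc1` gives 41200 nM and compound 2 `CN(C)c1ccc(-c2ccc(-c3ccc(-c4nc5ccccc5[nH]4)cc3)cc2)cc1` gives 100000 nM, the higher of the two numbers. Compound 3 `COc1ccc(-c2ccc(-c3ccc(-c4nc5ccccc5[nH]4)cc3)cc2)cc1OC` is the next to read, and it carries 3,4-dimethoxyphenyl in place of 4-(dimethylamino)phenyl on an aromatic carbon. Within the data shown here, only one measured step bears on this change, and it is modest. Compound 3 lacks the dimethylamino of a 2.4-fold higher number from compound 1 to compound 2 (0.39 log units; beyond the scatter), so a modest move to a lower number is expected. Among the measured compounds shown here, the expected step is a 2.0-fold lower number from compound 2 to compound 3 (0.30 log units; within the scatter), although no methoxy compound has been measured to test it. The estimate for compound 3 is 50000 nM, with an expected range of 18000 nM to 100000 nM.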

Compound 3, concentration for 50% growth inhibition: 47100 nM
The estimate for compound 3 lay 1.1-fold (0.03 log units) above the measured number; the range from low to high includes it.
By their numbers in this assay, from the lowest: compounds 1 and 3 (each within the scatter of the next); then compound 2.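

In this assay, the step to 3,4-dimethoxyphenyl gives a 2.1-fold lower number from compound 2 to compound 3 (0.33 log units; beyond the scatter), so replacing 4-(dimethylamino)phenyl on this aromatic carbon recovers part of the number's range. Measured against the unsubstituted phenyl, the same group gives a 1.1-fold higher number from compound 1 to compound 3 (0.06 log units; within the scatter), so this pair of methoxy groups shows no separation from compound 1 on this read-out. No available evidence explains the difference between these groups.

From the compounds shown here alone, a single methoxy group remains open, so the pair's contribution cannot be divided between its two positions. Also open, going by these compounds, is whether a primary amine or a carboxylic acid at this position would separate from compound 1.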